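Swapping Methyl for Chlorine on the Benzyl Ring

This account rests on a few compounds, and the source may have more. Where it says the series, first, only, none or still open, it means among the compounds named here.

Measured so far in an assay on membranes from liver for displacement of a labelled ligand from Sigma non-opioid intracellular receptor 1 (Rattus norvegicus), read by scintillation counting; on this read-out higher numbers stand for weaker inhibition and lower numbers for stronger inhibition:
- compound 1 `Cc1ccc(CN(C)CCCn2c(=O)oc3ccccc32)cc1`: 871 nM
- compound 2 `Cc1ccc(CN(C)CCCn2c(=O)oc3ccccc32)c(C)c1`: 1830 nM
- compound 3 `Cc1cccc(CN(C)CCCn2c(=O)oc3ccccc32)c1`: 1840 nM

Compound 3 gives the highest number of the three. Its value and that of compound 2 lie within the scatter of each other, while the step of a 2.1-fold higher number from compound 1 to compound 3 (0.32 log units; beyond the scatter) is beyond it, as is a 2.1-fold higher number from compound 1 to compound 2 (0.32 log units; beyond the scatter).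

Compound 4 `CN(CCCn1c(=O)oc2ccccc21)Cc1ccc(Cl)cc1` is the next member. The change is 4-chlorophenyl in place of 3-methylphenyl on a saturated chain carbon bound to an amine nitrogen.

Going by the values given here, no measured step swaps a methyl for a chlorine, so the guide is a 2.1-fold higher number from compound 1 to compound 3 (0.32 log units; beyond the scatter), where shifting a single group on the benzyl ring from the 4- to the 3-position raised the number modestly; moving a group back to the 4-position is therefore expected to lower it by a similar, modest amount. For compound 4 the estimate is 900 nM, between 350 nM and 2500 nM, an expected step of a 2.0-fold lower number from compound 3 to compound 4 (0.31 log units; beyond the scatter).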

Compound 4, inhibition constant: 1150 nM
Estimate against measurement, compound 4: 1.3-fold (0.11 log units) below, and the stated range covers the measured number.
By their numbers in this assay, from the lowest: compounds 1, 4, 2 and 3 (each within the scatter of the next, the first and the last beyond it).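

In this assay, 4-chlorophenyl and 4-methylphenyl cannot be told apart, since a 1.3-fold higher number from compound 1 to compound 4 (0.12 log units; within the scatter) stays within the scatter. The same holds for a 1.6-fold lower number from compound 3 to compound 4 (0.20 log units; within the scatter) and for a 1.6-fold lower number from compound 2 to compound 4 (0.20 log units; within the scatter), so compound 4 cannot be separated from any earlier compound, even though compound 1 and compound 3 lie beyond the scatter of each other.

From the compounds shown here alone, whether a methoxy group or a nitrile in place of the chlorine would also stay within the scatter remains open. No measurement at hand says why chlorine and methyl give such similar numbers here.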